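The compounds below may be only part of what the source reports. "The series", "measured", "known", "first", "only" and "open" are said of these compounds alone.

In a physicochemical assay, read by spectrophotometry, with a stated time of 6 min (on this read-out higher numbers stand for weaker inhibition and lower numbers for stronger inhibition), compound 1 (`COc1cc(/C=N/NC(=O)CCCc2nc3ccccc3c(=O)[nH]2)cc(OC)c1O`) gives 135000000 nM and compound 3 (`COc1cc(/C=N/NC(=O)CCc2nc3ccccc3c(=O)[nH]2)cc(OC)c1O`) gives 105000000 nM while compound 2 (`COc1cc(/C=N/NC(=O)CCCc2nc3ccccc3c(=O)[nH]2)cc(O)c1O`) has the lowest number of the three at 50000000 nM as measured. Compound 4 (`O=C(CCCc1nc2ccccc2c(=O)[nH]1)N/N=C/c1ccc(O)c(O)c1`) differs from compound 2 by hydrogen in place of methoxy on an aromatic carbon. Among the measured compounds shown here, the only measured step bearing on this change is a 2.7-fold lower number from compound 1 to compound 2 (0.43 log units; beyond the scatter) and it is modest, but there a methyl leaves an oxygen and the oxygen stays. For the measured compounds named here, no measured step removes a whole methoxy, so no firm direction is available and a step within the scatter is expected in this assay for this change. The expected step is a 1.2-fold higher number from compound 2 to compound 4 (0.08 log units; within the scatter) by this estimate. For compound 4 the estimated value is 60000000 nM with an expected range from 25000000 nM to 130000000 nM in this read-out.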

Compound 4, half-maximal inhibitory concentration: 50000000 nM
Estimate against measurement, compound 4: 1.2-fold (0.08 log units) above; the measured number falls inside the stated range.
By their numbers in this assay, from the lowest: compounds 2 and 4 (each within the scatter of the next); then compounds 3 and 1 (each within the scatter of the next).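

In this assay, among the compounds shown here, the earlier compounds showed only a methyl leaving an oxygen on this ring, a 2.7-fold lower number from compound 1 to compound 2 (0.43 log units; beyond the scatter). Here the whole methoxy leaves an aromatic carbon ortho to a hydroxy group, with no change at the digits printed from compound 2 to compound 4 (within the scatter), so at this position hydrogen in place of methoxy leaves the number within the scatter. Nothing available accounts for this result. Going by these compounds, whether an amine or a carboxylic acid on this aromatic carbon would move the number remains open. So does whether the same change behaves alike on the chain of compound 3.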